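The source may report more compounds than this note shows. Statements on the series, on what has been measured and on what is new or still open speak of the compounds shown alone.

Measured so far in a functional assay on LNCaP cells (Homo sapiens) for antiproliferative activity, read by propidium iodide staining, with a stated time of 96 h; a lower number here means a stronger inhibitor, a higher number a weaker inhibitor:
- compound 1 `CC(O)(CSc1ccc(OC(F)(F)F)cc1)C(=O)Nc1cccc(S(F)(F)(F)(F)F)c1`: 10300 nM
- compound 2 `CC(O)(CSc1cc(C(F)(F)F)cc(C(F)(F)F)c1)C(=O)Nc1cccc(S(F)(F)(F)(F)F)c1`: 4800 nM
- compound 3 `CC(O)(CS(=O)(=O)c1ccc(F)cc1)C(=O)Nc1ccc(S(F)(F)(F)(F)F)cc1`: 18200 nM

Compound 3 lies within the scatter of compound 1, and its number is higher than that of compound 2 by more than the scatter. Among the measured compounds shown here, no two measured compounds differ in only one place, so the series gives no direct measure of any single change.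

The next step leads to compound 4 `CC(O)(CS(=O)(=O)c1ccccc1OC(F)(F)F)C(=O)Nc1ccc(S(F)(F)(F)(F)F)cc1`, with 2-(trifluoromethoxy)phenyl in place of 4-fluorophenyl on a sulfonyl sulfur.

For the measured compounds named here, the only guide is indirect. Compound 2, at 4800 nM, stands lower than compound 3, but the two differ in more than one place, so this is weak support. At most a small move toward a lower number is expected in this assay, not clearly beyond the scatter. The estimated step is a 1.8-fold lower number from compound 3 to compound 4 (0.26 log units; within the scatter).

For compound 4 the estimated value is 10000 nM, with an expected range of 4000 nM to 25000 nM.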

Compound 4, half-maximal inhibitory concentration: 12700 nM
Estimate against measurement, compound 4: 1.3-fold (0.10 log units) below; low and high end bracket the measured number.
By their numbers in this assay, from the lowest: compound 2; then compounds 1, 4 and 3 (each within the scatter of the next).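

In this assay, among the compounds shown here, 2-(trifluoromethoxy)phenyl in place of 4-fluorophenyl on a sulfonyl sulfur gives a 1.4-fold lower number from compound 3 to compound 4 (0.16 log units; within the scatter), the first comparison that isolates a single change. At this position, the assay does not separate the two aryl groups, even though the entering group brings a hydrogen-bond acceptor that the leaving group lacks. No measurement at hand offers an explanation for this step.

From the compounds shown here alone, whether an amine or a carboxylic acid on the aromatic ring at this position would give a step beyond the scatter remains open. Compounds 1 and 2 differ from compounds 3 and 4 in more than one place, so those steps cannot be read, and the effect of the sulfonyl sulfur itself remains unresolved.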